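Trifluoromethyl for Carbamoyl: Expected Cytotoxicity of Compound 4

This account rests on a few compounds, and the source may have more. Where it says the series, first, only, none or still open, it means among the compounds named here.

Compound 1 `Cc1cc(C#N)cc(C)c1Oc1nc(NC2CCC(NCc3ccc(S(N)(=O)=O)cc3)CC2)nc2ccsc12` gives 3690 nM in an ADME assay on MT4 cells (Homo sapiens) for cytotoxicity, read by MTT assay, with a stated time of 5 days; on this read-out higher numbers stand for lower toxicity in this test and lower numbers for higher toxicity in this test.
Compound 2 `Cc1cc(C#N)cc(C)c1Oc1nc(NC2CCC(NCc3cccc(C(N)=O)c3)CC2)nc2ccsc12` gives 9210 nM in this assay.
Compound 3 `Cc1cc(C#N)cc(C)c1Oc1nc(NC2CCC(NCc3ccc(Br)cc3)CC2)nc2ccsc12` gives 3450 nM in this assay.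

Compound 2 gives the highest number of the three, and its distance to compound 1 and to compound 3 lies beyond the scatter in each case. Compound 4 `Cc1cc(C#N)cc(C)c1Oc1nc(NC2CCC(NCc3cccc(C(F)(F)F)c3)CC2)nc2ccsc12` differs from compound 2 in one place: trifluoromethyl in place of carbamoyl on an aromatic carbon. For the measured compounds named here, two measured steps bear on this change. a 2.5-fold higher number from compound 1 to compound 2 (0.40 log units; beyond the scatter), and a 2.7-fold lower number from compound 2 to compound 3 (0.43 log units; beyond the scatter); the second step, which also takes the carbamoyl group away, is the closer guide. A modest fall is therefore expected, a 2.3-fold lower number from compound 2 to compound 4 (0.36 log units; beyond the scatter). Compound 4 is estimated at 4000 nM, with a range from 1800 nM to 9000 nM.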

Compound 4, half-maximal cytotoxic concentration: 707 nM
For compound 4 the middle estimate is 5.7-fold (0.75 log units) above the measured one; the measured number lies below the stated range.
By their numbers in this assay, from the lowest: compound 4; then compounds 3 and 1 (each within the scatter of the next); then compound 2.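

In this assay, for the compounds shown here, this change on an aromatic carbon gives a 13-fold lower number from compound 2 to compound 4 (1.11 log units; beyond the scatter) and is the only step so far graded large, pointing to higher toxicity in this test. Taking carbamoyl away is not all that counts: compound 3 lacks it too, yet the steps read a 4.9-fold lower number from compound 3 to compound 4 (0.69 log units; beyond the scatter) and a 5.2-fold lower number from compound 1 to compound 4 (0.72 log units; beyond the scatter). No evidence is available to explain this fall.

As far as these compounds go, whether trifluoromethyl itself drives the fall remains open, as a methyl, chloro or carboxylic acid at this position would be needed to tell. A 3-bromophenyl compound would also separate the group from its place on the ring.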